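The compounds below may be only part of what the source reports. "The series", "measured", "known", "first", "only" and "open" are said of these compounds alone.

Measured compounds:
- compound 1, `COc1ccc2c(=O)c(/C=C/C(=O)NCc3ccccc3)coc2c1`: 376000 nM
- compound 2, `COc1ccc2c(=O)c(/C=C/C(=O)Nc3ccccc3Cl)coc2c1`: 1010000 nM
- compound 3, `COc1ccc2c(=O)c(/C=C/C(=O)Nc3ccccc3OC)coc2c1`: 1050000 nM

All three compounds share one core and differ only in the group carried on the amide nitrogen. In an ADME assay on HepG2 2.2.15 cells (Homo sapiens) for cytotoxicity, read by MTT assay, with stated times of 48 h and 9 days (on this read-out lower numbers stand for higher toxicity in this test and higher numbers for lower toxicity in this test), compound 1 gives the lowest of the three numbers, so it is the most toxic of the set in this test. The two anilide-type compounds sit higher: a 2.7-fold higher number from compound 1 to compound 2 (0.43 log units; beyond the scatter) and a 2.8-fold higher number from compound 1 to compound 3 (0.45 log units; beyond the scatter), while the two of them lie within the scatter of each other, a 1.0-fold higher number from compound 2 to compound 3 (0.02 log units; within the scatter).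

Compound 4, `COc1ccc2c(=O)c(/C=C/C(=O)Nc3ccc(Cl)cc3)coc2c1`, has not yet been measured. Its change from compound 1 is 4-chlorophenyl in place of benzyl on an amide-type nitrogen. Among the compounds with values here, the steps that bear on it are the two in which benzyl gave way to a substituted phenyl, both of modest size and both towards a higher number, with chloro and methoxy giving the same result. A modest step upward is therefore expected, a 2.4-fold higher number from compound 1 to compound 4 (0.38 log units; beyond the scatter), and compound 4 is expected to give about 900000 nM in this assay, most likely between 400000 nM and 2000000 nM.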

Compound 4, half-maximal cytotoxic concentration: 272000 nM
Compound 4: middle estimate off by 3.3-fold (0.52 log units), on the high side; the measured number lies below the stated range.
By their numbers in this assay, from the lowest: compounds 4 and 1 (each within the scatter of the next); then compounds 2 and 3 (each within the scatter of the next).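

Replacing benzyl with a substituted phenyl on the amide-type nitrogen does not by itself give a higher number in this assay: with 4-chlorophenyl, the result is a 1.4-fold lower number from compound 1 to compound 4 (0.14 log units; within the scatter). Among these compounds, the position of the chloro group on the phenyl ring makes a measurable difference, with 4-chlorophenyl in place of 2-chlorophenyl giving a 3.7-fold lower number from compound 2 to compound 4 (0.57 log units; beyond the scatter), and the change from 2-methoxyphenyl to 4-chlorophenyl gives a similar result, a 3.9-fold lower number from compound 3 to compound 4 (0.59 log units; beyond the scatter). Nothing available here explains why the 4-chlorophenyl compound falls with the benzyl compound rather than with the other two.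

On these data alone, it remains open where an unsubstituted phenyl group would fall relative to these four compounds. As far as these compounds go, a longer chain, such as phenethyl, or an amine or carboxylic acid on the ring, also remains untested in this set.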